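Methylsulfonyl for Chloro: Cytotoxicity Expected to Stay at Limit

This account rests on a few compounds, and the source may have more. Where it says the series, first, only, none or still open, it means among the compounds named here.

Compound 2 `CCOC(=O)CCCCCOc1cccc(CN(C(=O)c2ccc(-c3cccc(Cl)c3)cc2)C(C)C)c1` is one of two compounds examined in an ADME assay on HEK293 cells (Homo sapiens) for cytotoxicity, read by CellTiter-Glo and resazurin assay, with a stated time of 72 h; a lower number here means that less compound is needed, a higher number that more compound is needed for the effect. In this assay compound 2 reaches only a limit, > 18400 nM. Compound 1 `CCOC(=O)CCCCCOc1cccc(CN(C(=O)c2ccc(-c3cccc(-c4nnc(C)o4)c3)cc2)C(C)C)c1` likewise gives only a limit in this assay, > 26000 nM. For the measured compounds named here, the single measured step, a step that the two limits leave unreadable from compound 1 to compound 2, is the only comparison available. Compound 3 `CCOC(=O)CCCCCOc1cccc(CN(C(=O)c2ccc(-c3cccc(S(C)(=O)=O)c3)cc2)C(C)C)c1` differs from compound 2 by methylsulfonyl in place of chloro on an aromatic carbon. Going by the values given here, no measured step bears on this change, and the two limits the limit of > 18400 nM in this assay, at which 1 of the 2 values shown sits, and the limit of > 26000 nM in this assay, at which 1 of the 2 values shown sits, give no direction. Compound 3 is therefore expected to remain at a limit, with an expected step that the limit leaves unreadable from compound 2 to compound 3, nothing beyond the scatter. The estimate for compound 3 in this assay is 30000 nM, between 15000 nM and 60000 nM.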

Compound 3, half-maximal effective concentration: > 26000 nM
Compound 3: no number, only a limit; the forecaster's own chance of this, stated with the estimate: 85%; the middle value is on the limit's open side.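

For the compounds shown here, compound 3, like compound 1 and compound 2, gives only a limit in this assay, so no step among the three can be read. The compounds shown leave open the concentration at which any of them reaches half-maximal effect, and whether they differ at all.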